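The source may hold more compounds than are shown below. What is called first, only, known or untested is meant among the compounds shown, and "the series" means these compounds.

Measured so far in a functional assay, with a stated time of 150 min; on this read-out lower numbers stand for stronger inhibition and higher numbers for weaker inhibition:
compound 1 `CCOC(=O)c1cnn(-c2nc(-c3ccccc3O)c(C#N)c(=O)n2C)c1N`: 64 ug/mL
compound 2 `CCOC(=O)c1cnn(-c2nc(-c3ccc(N(C)C)cc3)c(C#N)c(=O)n2C)c1N`: 115 ug/mL

Within the data shown here, compound 2 holds the highest of these two numbers in this assay , and its only neighbour is compound 1, with the change giving a 1.8-fold higher number from compound 1 to compound 2 (0.25 log units; within the scatter), so the two values cannot be ordered. Compound 3 `CCOC(=O)c1cnn(-c2nc(-c3cccs3)c(C#N)c(=O)n2C)c1N` carries a different change at the same position: thiophen-2-yl in place of 4-(dimethylamino)phenyl on an aromatic carbon. Among the measured compounds shown here, no measured step involves a thiophen-2-yl group, so nothing known bears directly on this change; the one measured step at this position stayed within the scatter. Compound 3 is therefore expected to give a number close to that of compound 2, with the step of a 1.2-fold lower number from compound 2 to compound 3 (0.06 log units; within the scatter) not exceeding the scatter. The estimate for compound 3 in this assay is 100 ug/mL, within a range from 40 ug/mL to 250 ug/mL.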

Compound 3, half-maximal inhibitory concentration: 98 ug/mL
Compound 3: the middle estimate sits 1.0-fold (0.01 log units) above what was measured, and the stated range covers the measured number.
By their numbers in this assay, from the lowest: compounds 1, 3 and 2 (each within the scatter of the next).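

In this assay, compound 3 places a five-membered aromatic ring with one sulfur atom at a position that otherwise holds a substituted six-membered aromatic ring of carbon only in the compounds shown. Exchanging 4-(dimethylamino)phenyl for thiophen-2-yl, with 5 heavy atoms entering in place of 9, gives a 1.2-fold lower number from compound 2 to compound 3 (0.07 log units; within the scatter), and exchanging 2-hydroxyphenyl for thiophen-2-yl gives a 1.5-fold higher number from compound 1 to compound 3 (0.19 log units; within the scatter), so this position has now taken three different aromatic groups with no step beyond the scatter and the three compounds cannot be ordered. No independent measurement is available to explain this result.

On these data alone, all three compounds carry an aromatic ring at this position, so the effect of a non-aromatic group there remains open. An amine, a carboxylic acid or a longer alkyl chain on this carbon might or might not move the number beyond the scatter.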